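The source may hold more compounds than are shown below. What is called first, only, known or untested is meant among the compounds shown, and "the series" means these compounds.

For the measured compounds named here, in an assay on cells with melanin-concentrating hormone receptor 1 (Homo sapiens) as the target, read by radioligand binding (on this read-out lower numbers stand for stronger inhibition and higher numbers for weaker inhibition), compound 1 `CCCCCOc1cccc2ccc(N)nc12` gives 580 nM, the only number among the three values measured. Compound 2 `CC(CC(C)(C)C)Oc1cccc2ccc(N3CCCCC3)nc12` returns > 2000 nM, a limit of the assay rather than a number. Compound 3 `CC(CC(C)(C)C)Oc1cccc2cccnc12` likewise returns > 2000 nM, also a limit. The step that the two limits leave unreadable from compound 2 to compound 3 cannot be read, since both ends sit at the limit of > 2000 nM in this assay, at which 2 of the 3 values shown sit. Compound 4 `Nc1ccc2cccc(OCC3CCCO3)c2n1` differs from compound 1 by oxolan-2-yl in place of butyl on a saturated chain carbon bound to an oxygen on an aromatic ring. Going by the values given here, none of the measured steps concerns this change, as compounds 2 and 3 differ from compound 1 in other places and their one step is unreadable. With nothing comparable to lean on, a 1.0-fold higher number from compound 1 to compound 4 (0.01 log units; within the scatter) is estimated to stay within the usual scatter. Compound 4 is therefore expected near 600 nM, between 200 nM and 2000 nM.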

Compound 4, half-maximal inhibitory concentration: > 2000 nM
Compound 4 gave a limit, no number; the forecaster's own chance of this, stated with the estimate: 20%; at least 3.3-fold (0.52 log units) between middle value and limit.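

In this assay, oxolan-2-yl in place of butyl on a saturated chain carbon bound to an oxygen on an aromatic ring gives an at least 3.4-fold higher number from compound 1 to compound 4 (0.53 log units; beyond the scatter). For the compounds shown here, this is the first readable step at this place, and it shows that this position does not accept every group of similar size without a loss of inhibition. Compound 4 sits at a limit, not a number, and the full size of the step stays unknown: the limit of > 2000 nM in this assay, at which 3 of the 4 values shown sit.

Going by these compounds, whether the loss follows the ring or its oxygen stays open. A cyclopentylmethyl group or a longer chain at this place could separate the two.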